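This account rests on a few compounds, and the source may have more. Where it says the series, first, only, none or still open, it means among the compounds named here.

In an ADME assay on Vero cells (Chlorocebus sabaeus) for cytotoxicity, read by crystal violet staining (a lower number here means that less compound is tolerated, a higher number that more compound is tolerated), compound 1 `Clc1cccc(/N=N/N2CCCC2)c1` gives >= 100000 nM, which is a limit of the assay and not a number. Compound 2 `Fc1ccc(F)c(/N=N/N2CCCC2)c1` likewise gives only a limit, > 100000 nM. Compound 3 `FC(F)(F)c1cccc(/N=N/N2CCCC2)c1` has not yet been measured, and it carries trifluoromethyl in place of chloro on an aromatic carbon of the core of compound 1 (trifluoromethyl in place of chloro on an aromatic carbon). Among the measured compounds shown here, no two measured compounds here differ in one place alone, so the data offer no direct guide to the size of this change. With compound 1 at the limit of >= 100000 nM, no step beyond the usual scatter is expected in this assay, in either direction. The expected change is a number no higher from compound 1 to compound 3 (the limit leaves the size open). For compound 3 the estimated value is 100000 nM, with an expected range of 40000 nM to 200000 nM.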

Compound 3, half-maximal cytotoxic concentration: > 100000 nM
Compound 3: a limit, no number; the forecaster's own chance of this, stated with the estimate: 75%; the middle value sits exactly at the limit.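

No new step can be read: compound 1 and compound 3 each give only a limit and not a number, so the change from chloro to trifluoromethyl has no readable size. In this assay the compounds shown leave open at what concentration any of them becomes cytotoxic and whether trifluoromethyl and chloro differ at all.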